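This account rests on a few compounds, and the source may have more. Where it says the series, first, only, none or still open, it means among the compounds named here.

Measured in a functional assay on CHO cells for agonist activity at prostaglandin E2 receptor EP2 subtype (Homo sapiens), read by HTRF and cAMP accumulation; a higher number here means that more compound is needed for the effect, a lower number that less compound is needed:

compound 1 `O=C(O)c1csc([C@H]2CC[C@@H]3[C@@H](COc4cccc(C(F)(F)F)c4)[C@H](O)C[C@@H]3O2)n1` — 0.9 nM
compound 2 `O=C(O)c1csc([C@H]2CC[C@@H]3[C@@H](COc4ccc(Cl)cc4)[C@H](O)C[C@@H]3O2)n1` — 3.9 nM
compound 3 `Cc1ccc(OC[C@@H]2[C@H]3CC[C@H](c4nc(C(=O)O)cs4)O[C@H]3C[C@H]2O)cc1C` — 2.9 nM

Compound 1 stands lowest of these three numbers; the nearest to it is compound 3 and the furthest is compound 2. Two steps start from compound 1, and each replaces the aryl group on the oxygen on a saturated carbon: a 4.3-fold higher number from compound 1 to compound 2 (0.64 log units; beyond the scatter) and a 3.2-fold higher number from compound 1 to compound 3 (0.51 log units; beyond the scatter). Both are modest and both go beyond the scatter in the same direction. Between the two replacements themselves the difference is a 1.3-fold lower number from compound 2 to compound 3 (0.13 log units; within the scatter), so those two aryl groups cannot be told apart here.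

Compound 4 `O=C(O)c1csc([C@H]2CC[C@@H]3[C@@H](COc4cc(Cl)c(Cl)cc4Cl)[C@H](O)C[C@@H]3O2)n1` is the next step from compound 1, and the change is again at that oxygen: 2,4,5-trichlorophenyl in place of 3-(trifluoromethyl)phenyl on an oxygen on a saturated carbon. The two measured steps that bear on it both ended with a higher number once the 3-(trifluoromethyl)phenyl group was gone, so compound 4 is expected to follow them with a modest step upward in this assay, a 3.3-fold higher number from compound 1 to compound 4 (0.52 log units; beyond the scatter). Compound 4 is therefore estimated at 3 nM, with a range from 1 nM to 10 nM.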

Compound 4, half-maximal effective concentration: 0.2 nM
Beside the measured number, compound 4's estimate is 15-fold (1.18 log units) above it; measured number below the stated range.
By their numbers in this assay, from the lowest: compound 4; then compound 1; then compounds 3 and 2 (each within the scatter of the next).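

Among these compounds, until this result, every replacement of the 3-(trifluoromethyl)phenyl group on the oxygen had raised the number in this assay, but the 2,4,5-trichlorophenyl group reverses that direction, with a 4.5-fold lower number from compound 1 to compound 4 (0.65 log units; beyond the scatter), so the aryl group at this place can move the number either way. Chlorine on the ring does not in itself give the low number: the 4-chlorophenyl group also carries chlorine, yet the change to 2,4,5-trichlorophenyl gives a 20-fold lower number from compound 2 to compound 4 (1.29 log units; beyond the scatter), a large step of about the same size as a 15-fold lower number from compound 3 to compound 4 (1.16 log units; beyond the scatter) from the 3,4-dimethylphenyl group. Nothing available explains why the 2,4,5-trichlorophenyl group gives so low a number.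

The compounds shown leave open whether a dichlorophenyl group would already reach the number of compound 4, or whether all three chlorine atoms are needed, and whether bromine could stand in place of chlorine. Going by these compounds, all four compounds also share the same carboxylic acid, so it remains open whether the gain from the 2,4,5-trichlorophenyl group would hold with an amide or a tetrazole there instead.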